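This account rests on a few compounds, and the source may have more. Where it says the series, first, only, none or still open, it means among the compounds named here.

Measured compounds in a functional assay on NCI-H460 cells (Homo sapiens) for cytotoxicity, read by sulforhodamine B assay; a lower number here means a stronger inhibitor of growth, a higher number a weaker inhibitor of growth:
Compound 1 `COc1ccc(/C=N\NC(=S)NC(C)(C)CCC[C@](C)(O)[C@@H]2CC=C(C)CC2)cc1` gives 5100 nM.
Compound 2 `CC1=CC[C@@H]([C@@](C)(O)CCCC(C)(C)NC(=S)N/N=C\c2ccc(O)cc2)CC1` gives 1460 nM.
Compound 3 `CC1=CC[C@@H]([C@@](C)(O)CCCC(C)(C)NC(=S)N/N=C\c2cccc(Cl)c2)CC1` gives 44300 nM.

Compound 3 stands highest of the three numbers, weakest in this assay: an 8.7-fold higher number from compound 1 to compound 3 (0.94 log units; beyond the scatter) and a 30-fold higher number from compound 2 to compound 3 (1.48 log units; beyond the scatter), both beyond the scatter. Among the other pair, a 3.5-fold lower number from compound 1 to compound 2 (0.54 log units; beyond the scatter).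

Compound 4 `CC1=CC[C@@H]([C@@](C)(O)CCCC(C)(C)NC(=S)N/N=C(/C)c2ccccc2)CC1` is not yet measured. Relative to compound 3 the change is a group of 9 heavy atoms (8 carbon, 1 nitrogen; one six-membered aromatic ring of carbon only) in place of a group of 9 heavy atoms (7 carbon, 1 nitrogen, 1 chlorine; one six-membered aromatic ring of carbon only), on an amide-type nitrogen. The chlorine leaves the ring and a methyl enters on the carbon with the double bond to nitrogen. Going by the values given here, no measured step does exactly either thing. Among the compounds with values here, the steps that bear on it are the two swaps of the same aryl group, ending at compound 3, and both raised the number, one modest and one large; compound 3 is thus the poorest anchor and a move away from its aryl group has so far meant a lower number. Within the data shown here, the added methyl has no precedent, so the range is kept wide. For compound 4 a lower number than compound 3 is expected, a 4.4-fold lower number from compound 3 to compound 4 (0.65 log units; beyond the scatter), landing near compound 1. The estimate for compound 4 is 10000 nM, with a range of 3000 nM to 40000 nM.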

Compound 4, concentration for 50% growth inhibition: 12600 nM
For compound 4 the middle estimate is 1.3-fold (0.10 log units) below the measured one; the measured number falls inside the stated range.
By their numbers in this assay, from the lowest: compound 2; then compound 1; then compound 4; then compound 3.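

In this assay, the group on the amide-type nitrogen in compound 4 holds neither chlorine nor oxygen, and the change gives a 3.5-fold lower number from compound 3 to compound 4 (0.55 log units; beyond the scatter); the loss of chlorine and the gain of methyl arrive together and cannot be told apart in this step. The same group still gives higher numbers than both oxygen-bearing groups, with a 2.5-fold higher number from compound 1 to compound 4 (0.39 log units; beyond the scatter) and an 8.6-fold higher number from compound 2 to compound 4 (0.94 log units; beyond the scatter), so among these four compounds the oxygen-bearing groups hold the two lowest numbers and the chlorine-bearing group the highest. No measurement available here gives a cause for these steps.

On these data alone, the effect of the methyl alone remains open, with the aromatic ring held constant. Also open, as far as these compounds go, is how an amine or a carboxylic acid on that ring, or a longer chain in place of the methyl, would compare.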